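From ethoxy to butoxy: a step still unmeasured

A few compounds are considered here, and "the series" means these few. Any claim that something is new, unique, unknown or untested is made for them only; others in the source may bear on it.

In a functional assay for inhibition, with Rattus norvegicus as the target, at pH 7.35 (on this read-out lower numbers stand for stronger inhibition and higher numbers for weaker inhibition), compound 1 (`CCC(NC(=O)C(CC(C)C)NC(=O)OCc1ccccc1)C(=O)C(=O)OC`) gives 280000 nM and compound 2 (`CCOC(=O)C(=O)C(CC)NC(=O)C(CC(C)C)NC(=O)OCc1ccccc1`) gives 300000 nM. These two numbers are all there is so far, and compound 2 stands within the scatter of compound 1. Compound 3 (`CCCCOC(=O)C(=O)C(CC)NC(=O)C(CC(C)C)NC(=O)OCc1ccccc1`) differs from compound 2 by ethyl in place of hydrogen on a saturated chain carbon, two bonds along the chain from an oxygen next to a carbonyl group, ethyl in place of hydrogen on a saturated chain carbon, which reads as ethoxy to butoxy. Going by the values given here, only one measured step bears on this, the methyl to ethyl change in the same chain. That step, a 1.1-fold higher number from compound 1 to compound 2 (0.03 log units; within the scatter), stayed within the scatter, so no change beyond the scatter is expected in this assay, although a single step is thin support. The expected step is a 1.2-fold lower number from compound 2 to compound 3 (0.06 log units; within the scatter), with no firm direction. Compound 3 is estimated at 260000 nM, with an expected range of 120000 nM to 550000 nM.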

Compound 3, half-maximal inhibitory concentration: 28000 nM
Compound 3: the middle estimate sits 9.3-fold (0.97 log units) above what was measured; the whole stated range lies above it.
By their numbers in this assay, from the lowest: compound 3; then compounds 1 and 2 (each within the scatter of the next).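

In this assay, this position proves responsive to chain length: the methyl to ethyl change had stayed within the scatter, whereas ethoxy to butoxy gives an 11-fold lower number from compound 2 to compound 3 (1.03 log units; beyond the scatter) and the full extension gives a 10-fold lower number from compound 1 to compound 3 (1.00 log units; beyond the scatter). Ethyl in place of hydrogen, two bonds along the chain from an oxygen next to a carbonyl group, is thus the first change among these compounds to move the number beyond the scatter, so the response across compounds 1, 2 and 3 is uneven rather than stepwise. Nothing available explains why the butoxy chain departs from the shorter ones.

The compounds shown end at butoxy, so it remains open whether a longer chain such as hexyl would carry the trend further or reverse it. Equally open, going by these compounds, is how a branched isobutyl group, a benzyl group or a chain ending in an amine would fare at this position.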